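The source may report more compounds than this note shows. Statements on the series, on what has been measured and on what is new or still open speak of the compounds shown alone.

Measured compounds:
- compound 1, `CCCCCCCCCCCCCCc1ccc(NC(=O)Nc2c(C(C)C)cccc2C(C)C)cc1`: 500 nM
- compound 2, `CCCCCCCCCCCCCc1ccc(NC(=O)Nc2c(C(C)C)cccc2C(C)C)cc1`: 11 nM
- compound 3, `CCCc1ccc(NC(=O)Nc2c(C(C)C)cccc2C(C)C)cc1`: 38 nM

In an assay on isolated protein for inhibition of acyl-CoA:cholesterol acyltransferase (Oryctolagus cuniculus) (on this read-out lower numbers stand for stronger inhibition and higher numbers for weaker inhibition), compound 1 gives the highest of the three numbers, so it is the weakest of the measured compounds. Compound 4, `CCc1ccc(NC(=O)Nc2c(C(C)C)cccc2C(C)C)cc1`, has not yet been measured. It differs from compound 1 by hydrogen in place of dodecyl on a saturated chain carbon, two bonds along the chain from an aromatic carbon, leaving an ethyl chain on the shared core in place of the long tetradecyl chain.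

Among the compounds with values here, two measured steps bear on this. Shortening the chain by a single carbon gave a 45-fold lower number from compound 1 to compound 2 (1.66 log units; beyond the scatter), and cutting it down to propyl gave a 13-fold lower number from compound 1 to compound 3 (1.12 log units; beyond the scatter). The long chain of compound 1 therefore appears to be the least favourable of those tested, while the shorter propyl chain of compound 3 still leaves a weaker number than the tridecyl chain of compound 2, as shown by a 3.5-fold higher number from compound 2 to compound 3 (0.54 log units; beyond the scatter). Going one carbon further, to ethyl, is expected to give a large drop in this assay, roughly an 8.3-fold lower number from compound 1 to compound 4 (0.92 log units; beyond the scatter). Compound 4 is thus estimated at 60 nM, with a likely range from 15 nM to 250 nM.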

Compound 4, half-maximal inhibitory concentration: 100 nM
The estimate for compound 4 lay 1.7-fold (0.22 log units) below the measured number; the range from low to high includes it.
By their numbers in this assay, from the lowest: compound 2; then compound 3; then compound 4; then compound 1.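

In this assay, the ethyl chain improves on the tetradecyl chain, with a 5.0-fold lower number from compound 1 to compound 4 (0.70 log units; beyond the scatter), but it falls short of the propyl chain, with a 2.6-fold higher number from compound 3 to compound 4 (0.42 log units; beyond the scatter), and of the tridecyl chain, with a 9.1-fold higher number from compound 2 to compound 4 (0.96 log units; beyond the scatter). Removing a single end methyl therefore has no fixed effect on the shared core, and its direction depends on the chain it is taken from: the same change on two cores in this assay, a 45-fold lower number (1.66 log units; beyond the scatter) from compound 1 to compound 2 and a 2.6-fold higher number (0.42 log units; beyond the scatter) from compound 3 to compound 4, 120-fold (2.08 log units) apart, beyond the scatter of two such steps The same holds for replacing an undecyl stretch with hydrogen: the same change on two cores in this assay, a 13-fold lower number (1.12 log units; beyond the scatter) from compound 1 to compound 3 and a 9.1-fold higher number (0.96 log units; beyond the scatter) from compound 2 to compound 4, 120-fold (2.08 log units) apart, beyond the scatter of two such steps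

Chains of middle length, such as hexyl or decyl, remain open, so the course of the read-out from propyl up to tridecyl is unknown. Also open, from the compounds shown here alone, is how a chain ending in an amine or a carboxylic acid would read in this assay.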